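Swapping Bromo for Nitro in a Non-Cytotoxic Ester Series

The source may hold more compounds than are shown below. What is called first, only, known or untested is meant among the compounds shown, and "the series" means these compounds.

Compound 2 `O=C(Oc1ccc(Cl)cc1C(=O)Nc1ccc(Cl)c(Cl)c1)c1ccc(Br)cc1` was tested in an ADME assay on HepG2 cells (Homo sapiens) for cytotoxicity, read by MTT assay, with a stated time of 72 h (on this read-out higher numbers stand for weaker inhibition and lower numbers for stronger inhibition), where it gave > 50000 nM, a limit of the assay rather than a number. Compound 1 `O=C(Oc1ccc(Br)cc1C(=O)Nc1ccc(C(F)(F)F)cc1)c1ccc(Br)cc1` likewise gave > 50000 nM, also a limit. Compound 3 `O=C(Oc1ccc(Cl)cc1C(=O)Nc1ccc(C(F)(F)F)cc1)c1ccc(Br)cc1` gave > 50000 nM, again a limit. The steps a step that the two limits leave unreadable from compound 1 to compound 3 and a step that the two limits leave unreadable from compound 2 to compound 3 therefore cannot be sized, because every value sits at the limit of > 50000 nM in this assay, at which 3 of the 3 values shown sit. Compound 4 `O=C(Oc1ccc(Cl)cc1C(=O)Nc1ccc(Cl)c(Cl)c1)c1ccc([N+](=O)[O-])cc1` differs from compound 2 by nitro in place of bromo on an aromatic carbon. No measured step here touches a nitro group, so this change is untested, and the uniformly weak inhibition gives no reason to expect a readable step in this assay. Compound 4 is therefore expected to give about 60000 nM, within 20000 nM to 200000 nM, an expected step that the limit leaves unreadable from compound 2 to compound 4.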

Compound 4, half-maximal inhibitory concentration: > 50000 nM
Compound 4: no number, only a limit (the forecaster's own chance of this, stated with the estimate: 75%); the middle value lies beyond the limit too.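

In this assay, among these compounds, compound 2 and compound 4 both sit at a limit, so no step between them can be read. Going by these compounds, whether nitro in place of bromo changes the inhibition at all stays open.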